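A few compounds are considered here, and "the series" means these few. Any claim that something is new, unique, unknown or untested is made for them only; others in the source may bear on it.

Measured so far in this series:

- compound 1, `CCCCCCCCCCCCCCCCCCNC(=O)[C@H]1CSC(Cc2ccccc2)N1`: in a functional assay on TSU-Pr1 cells for antiproliferative activity against TSU (Homo sapiens), read by sulforhodamine B assay (a lower number here means a stronger inhibitor, a higher number a weaker inhibitor), compound 1 gives 11200 nM
- compound 2, `CCCCCCCCCCCCCCCCCCNC(=O)[C@H]1CSC(c2c(Cl)cccc2Cl)N1`: in this assay compound 2 gives 20000 nM
- compound 3, `CCCCCCCCCCCCCCCCCCNC(=O)[C@H]1CSC(c2ccc(F)c(Br)c2)N1`: in this assay compound 3 gives 14000 nM

On the numbers shown compound 3 falls between the other two, yet all three values lie within the scatter of one another: its nearest neighbour is compound 1 (a 1.3-fold higher number from compound 1 to compound 3 (0.10 log units; within the scatter)), its furthest compound 2 (a 1.4-fold lower number from compound 2 to compound 3 (0.15 log units; within the scatter)). Nothing in the set separates the three aryl variants on the saturated ring carbon.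

Compound 4, `CCCCCCCCCCCCCCCCCCNC(=O)[C@H]1CSC(c2ccc(C)cc2)N1`, is the next variation at that position: 4-methylphenyl in place of 3-bromo-4-fluorophenyl on a saturated ring carbon. Within the data shown here, the steps that bear on it are the three earlier swaps at the same place, a 1.8-fold higher number from compound 1 to compound 2 (0.25 log units; within the scatter), a 1.3-fold higher number from compound 1 to compound 3 (0.10 log units; within the scatter) and a 1.4-fold lower number from compound 2 to compound 3 (0.15 log units; within the scatter), each within the scatter. The group entering here is again a single substituted phenyl with no donor or acceptor, so no reason appears in the data for a step of a different size. The expected step in this assay is no change at the digits printed from compound 3 to compound 4 (within the scatter), that is, none beyond the scatter. Compound 4 is therefore estimated at 14000 nM, with a range of 6000 nM to 35000 nM.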

Compound 4, half-maximal inhibitory concentration: 8000 nM
Compound 4: middle estimate off by 1.8-fold (0.24 log units), on the high side; the measured number falls inside the stated range.
By their numbers in this assay, from the lowest: compounds 4, 1, 3 and 2 (each within the scatter of the next, the first and the last beyond it).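

In this assay this position gives its first step beyond the scatter: a 2.5-fold lower number from compound 2 to compound 4 (0.40 log units; beyond the scatter) when 4-methylphenyl replaces 2,6-dichlorophenyl, a modest change that shows the group on this saturated ring carbon can move the number at least somewhat. The separation is limited, as a 1.8-fold lower number from compound 3 to compound 4 (0.24 log units; within the scatter) and a 1.4-fold lower number from compound 1 to compound 4 (0.15 log units; within the scatter) both stay within the scatter, so 4-methylphenyl stands apart only from 2,6-dichlorophenyl and not from 3-bromo-4-fluorophenyl or benzyl. No measurement in hand accounts for the gap between compound 2 and compound 4.

The compounds shown leave open whether a group carrying an amine, a hydroxyl or a carboxylic acid at this ring carbon would give a step larger than the modest one seen so far, as every group here has no hydrogen-bond donors or acceptors. Also open, as far as these compounds go, is whether the same ranking of compound 2 and compound 4 would hold with a shorter chain on the amide, because all four compounds share one long chain there and the core.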